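The source may report more compounds than this note shows. Statements on the series, on what has been measured and on what is new or still open speak of the compounds shown alone.

Measured in an ADME assay on HFF cells (Homo sapiens) for cytotoxicity, read by MTT assay, with a stated time of 72 h; on this read-out higher numbers stand for weaker inhibition and lower numbers for stronger inhibition:

- Compound 1 `O=C1O/C(=C\Cn2cc(-c3ccc(Br)cc3)nn2)C(OCc2ccccc2)=C1OCc1ccccc1`: > 100000 nM. This value is a limit.
- Compound 2 `CCCCc1cn(C[C@H](O)[C@H]2OC(=O)C(OCc3ccccc3)=C2OCc2ccccc2)nn1`: 26300 nM.
- Compound 3 `CC(C)(C)OC(=O)N1CCN(C(=S)SCc2cn(C[C@H](O)[C@H]3OC(=O)C(OCc4ccccc4)=C3OCc3ccccc3)nn2)CC1`: 60 nM.

Of the two values that are actual numbers, compound 3 at 60 nM lies below compound 2 at 26300 nM, and the gap is well beyond the scatter. Compound 2 therefore holds the higher number.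

Compound 4 `CC(C)(C)c1cn(C[C@H](O)[C@H]2OC(=O)C(OCc3ccccc3)=C2OCc2ccccc2)nn1` has tert-butyl in place of butyl on an aromatic carbon. The two have the same atoms, joined differently. For the measured compounds named here, no measured pair isolates this change, so the expectation starts from compound 2 at 26300 nM, with no shift beyond the scatter in either direction. The estimated change is a 1.1-fold higher number from compound 2 to compound 4 (0.06 log units; within the scatter).

For compound 4 the expected value is 30000 nM, with an estimated range of 12000 nM to 90000 nM.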

Compound 4, half-maximal inhibitory concentration: 13300 nM
The estimate for compound 4 lay 2.3-fold (0.35 log units) above the measured number; the measured number falls inside the stated range.
By their numbers in this assay, from the lowest: compound 3; then compounds 4 and 2 (each within the scatter of the next). At a limit, above all of these: compound 1.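

In this assay, for the compounds shown here, tert-butyl in place of butyl on an aromatic carbon gives the only step that can be read: a 2.0-fold lower number from compound 2 to compound 4 (0.30 log units; within the scatter). At this position, then, the two four-carbon groups are not told apart by this read-out, and the chain's branching alone gives no shift beyond the scatter. No measurement shown bears on the reason for this result.

Open, on these data alone, is whether an amine, a carboxylic acid or a longer chain at this position would give a step beyond the scatter. Also open, as far as these compounds go, is whether tert-butyl and butyl would stay as close on the core of compound 1.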